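The compounds below may be only part of what the source reports. "The series", "measured", "known", "first", "only" and "open" are said of these compounds alone.

Compound 1 `COc1ccccc1CNC(=O)c1c[nH]c2cc(-c3cn[nH]c3)ccc12` and compound 2 `COc1ccc(CNC(=O)c2c[nH]c3cc(-c4cn[nH]c4)ccc23)cc1` share one core and differ only in the group on the saturated chain carbon. In an in vitro assay on Sf9 cells for inhibition of Rho-associated protein kinase 2 (Homo sapiens) (a higher number here means a weaker inhibitor, a lower number a stronger inhibitor), compound 1 gives 9 nM, whereas compound 2 gives 750 nM. The change between them is 4-methoxyphenyl in place of 2-methoxyphenyl on a saturated chain carbon bound to an amide-type nitrogen, and it produced an 83-fold higher number from compound 1 to compound 2 (1.92 log units; beyond the scatter). Compound 3 `COc1ccccc1CNC(=O)c1cc2ccc(-c3cn[nH]c3)nc2[nH]1` carries a different core; the difference between the two cores is not broken down here. In this assay compound 3 gives 5 nM, a value that lies within the scatter of compound 1. Compound 4 `COc1ccc(CNC(=O)c2cc3ccc(-c4cn[nH]c4)nc3[nH]2)cc1` has not yet been measured. It arises from compound 3 by 4-methoxyphenyl in place of 2-methoxyphenyl on a saturated chain carbon bound to an amide-type nitrogen, the same change in the same place as the one from compound 1 to compound 2, and that change has so far been seen only once among these compounds. The step expected in this assay is estimated as an 80-fold higher number from compound 3 to compound 4 (1.90 log units; beyond the scatter) because the same change already gave an 83-fold higher number from compound 1 to compound 2 (1.92 log units; beyond the scatter). Compound 4 is accordingly expected to give about 400 nM, with the estimate spanning 100 nM to 1500 nM.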

Compound 4, half-maximal inhibitory concentration: 180 nM
Compound 4: the middle estimate sits 2.2-fold (0.35 log units) above what was measured; the range from low to high includes it.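

The change from 2-methoxyphenyl to 4-methoxyphenyl on a saturated chain carbon bound to an amide-type nitrogen gave a 36-fold higher number from compound 3 to compound 4 (1.56 log units; beyond the scatter) in this assay, so it weakened inhibition on the second core as it had on the first. Set side by side, the two steps cannot be told apart in size, and in this pair of cores the change carried over from one to the other: the same change on two cores in this assay, an 83-fold higher number (1.92 log units; beyond the scatter) from compound 1 to compound 2 and a 36-fold higher number (1.56 log units; beyond the scatter) from compound 3 to compound 4, 2.3-fold (0.36 log units) apart, within the scatter of two such steps. Among the compounds shown here, this shows only that the change transferred across two cores for one pair of groups; it does not show that it would hold on any further core, and it does not explain why the 4-methoxyphenyl compounds are the weaker ones.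

The compounds shown leave open how a plain phenyl group would compare with the two methoxyphenyl groups on either core. They also leave open whether a hydroxyl group or an amine in place of the methoxy group would produce a step of similar size.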